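The compounds below may be only part of what the source reports. "The series", "measured", "known", "first", "only" and "open" are said of these compounds alone.

Measured so far in an ADME assay on NCM460 cells (Homo sapiens) for cytotoxicity, read by CCK-8 assay, with a stated time of 48 h; on this read-out higher numbers stand for weaker inhibition and lower numbers for stronger inhibition:
- compound 1 `COc1ccc(/C=C\c2cc(OC)c(OC)c(OC)c2)cc1OCc1ccc(CN2C[C@H](O)C[C@@H]2C(=O)O)cc1`: > 50000 nM (a limit, not a number)
- compound 2 `COc1ccc(/C=C\c2cc(OC)c(OC)c(OC)c2)cc1OCc1ccc(CN2CCCC[C@H]2C(=O)O)cc1`: > 50000 nM (a limit, not a number)
- compound 3 `COc1ccc(/C=C\c2cc(OC)c(OC)c(OC)c2)cc1OCc1ccc(CNCCN(C)C)cc1`: 35000 nM

Among the measured compounds shown here, compound 3, at 35000 nM, holds the only true number in this small set. Compound 1 and compound 2 give no number, only (the limit of > 50000 nM in this assay, at which 2 of the 3 values shown sit).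

Compound 4 `COc1ccc(/C=C\c2cc(OC)c(OC)c(OC)c2)cc1OCc1ccc(CN2CC[C@@H](O)C2)cc1` keeps the shared core and alters one group, on a saturated chain carbon bound to an aromatic carbon: 3-hydroxypyrrolidin-1-yl in place of (2-(dimethylamino)ethyl)amino on a saturated chain carbon bound to an aromatic carbon. The (2-(dimethylamino)ethyl)amino chain leaves and the 3-hydroxypyrrolidin-1-yl ring enters.

For the measured compounds named here, two measured steps bear on this change: an at least 1.4-fold lower number from compound 1 to compound 3 (0.15 log units; that floor lies within the scatter) and an at least 1.4-fold lower number from compound 2 to compound 3 (0.15 log units; that floor lies within the scatter). Each replaces a ring group with the same chain that compound 4 gives up, so each runs in the opposite sense to the change here. Both are only floors, and both floors lie within the scatter. The third step, a step that the two limits leave unreadable from compound 1 to compound 2, offers no size to work with. Neither ring group measured so far is the one entering here, so the data give no firm lead, and no step beyond the scatter is expected. The expected change is a 1.1-fold higher number from compound 3 to compound 4 (0.06 log units; within the scatter). The expectation is anchored on compound 3 at 35000 nM. The reading for compound 4 could also turn out to be only a limit. For compound 4 the estimated value is 40000 nM, with an expected range of 18000 nM to 80000 nM.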

Compound 4, half-maximal inhibitory concentration: 53000 nM
Compound 4: middle estimate off by 1.3-fold (0.12 log units), on the low side, within the range that was stated.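

In this assay, replacing the open (2-(dimethylamino)ethyl)amino chain with the 3-hydroxypyrrolidin-1-yl ring, on a saturated chain carbon bound to an aromatic carbon, gives a 1.5-fold higher number from compound 3 to compound 4 (0.18 log units; within the scatter), so at this place the chain and this ring cannot be told apart on this read-out. Compound 4 is also the first compound shown with a ring group at this place that gives a true number rather than a limit, which means that a ring at this place can be compared directly with the chain. The steps to compound 4 from compound 1 and from compound 2 cannot be read, because each starts from a limit and not from a number: the limit of > 50000 nM in this assay, at which 2 of the 4 values shown sit.

Among the compounds shown here, whether a morpholine ring, a piperazine ring or a longer amine chain at this place would give a step beyond the usual scatter remains open, since no step that can be read here goes beyond it. The mirror-image form of the 3-hydroxypyrrolidin-1-yl ring also remains open, so the compounds shown cannot say whether the defined stereocentre of compound 4 matters in this assay.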